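The compounds below may be only part of what the source reports. "The series", "measured", "known", "first", "only" and "open" are said of these compounds alone.

All compounds here were tested in a functional assay on SEM cells (Homo sapiens) for cytotoxicity, read by MTT assay, with a stated time of 72 h (on this read-out higher numbers stand for weaker inhibition and lower numbers for stronger inhibition), a read-out of how much of each substance is needed to reduce the signal from the cells. Compound 1 `C/C=C(\C)C(=O)O[C@H]1C[C@@]2(C)O[C@H]2[C@@H](OC(C)=O)[C@@]2(C)CC[C@@](O)(C(C)C)[C@H]12` gives only a limit of the measurement, > 100000 nM, rather than a number. Compound 2 `COc1ccc(C(=O)O[C@H]2CC(C)=C[C@H](O)[C@@]3(C)[C@@H](OC(C)=O)C[C@@](O)(C(C)C)[C@H]23)cc1` gives 18100 nM. Compound 3 `C=C1C[C@H](OC(=O)c2ccc(O)cc2)[C@@H]2[C@](C)(CC[C@@]2(O)C(C)C)C[C@@H]1O` gives 34700 nM. Of the two numbers recorded, compound 2 has the lower one, but its gap to compound 3 lies within the usual scatter of repeated measurements, so the two cannot be told apart on this evidence alone.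

Compound 4 `COc1ccc(C(=O)O[C@H]2CC(C)=C[C@H](OC(C)=O)[C@@]3(C)[C@@H](OC(C)=O)C[C@@](O)(C(C)C)[C@H]23)cc1` has not yet been measured in this assay. It differs from compound 2 in one place: acetyl in place of hydrogen on an oxygen on a saturated carbon. Cut one bond further out, the change reads hydroxy to acetoxy. Within the data shown here, no pair of measured compounds differs by this single change, so its effect cannot be read off the data and has to be estimated. For a change of this size, no step beyond the scatter is expected in this assay, in either direction. The estimated step of a 1.2-fold lower number from compound 2 to compound 4 (0.08 log units; within the scatter) is therefore small. Compound 4 is expected to give about 15000 nM, most likely between 5000 nM and 50000 nM.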

Compound 4, half-maximal inhibitory concentration: 15000 nM
The estimate for compound 4 equals the measured number at the digits printed; the range from low to high includes it.
By their numbers in this assay, from the lowest: compounds 4, 2 and 3 (each within the scatter of the next, the first and the last beyond it). At a limit, above all of these: compound 1.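

In this assay, replacing the hydrogen on this oxygen with acetyl gives a 1.2-fold lower number from compound 2 to compound 4 (0.08 log units; within the scatter), a step within the scatter, so in this pair the hydroxy group can be swapped for acetoxy without a measurable change in the read-out. Compounds 2 and 4 are the only pair shown that differs in one place, which makes this the one direct reading of what a single change does, and it concerns an oxygen on a saturated carbon that could previously be discussed only by estimate. Both values are true numbers, whereas compound 1 remains the only compound without one, and its entry is a limit: the limit of > 100000 nM in this assay, at which 1 of the 4 values shown sits.

Going by these compounds, what stays open is how far this oxygen accepts other groups, for example a longer chain such as a butanoyl ester, a benzoyl ester, or an amine in place of the hydroxy group. A single pair also cannot tell whether the same swap from hydroxy to acetoxy would be equally silent on the cores of compound 1 or compound 3, so no general rule for this position follows yet.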